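Isopropyl to Benzyloxy on the Amide Carbonyl

The source may report more compounds than this note shows. Statements on the series, on what has been measured and on what is new or still open speak of the compounds shown alone.

Compound 2 `CC(C)C(=O)NC(C(=O)N1CCC(c2ccc(Cl)cc2)CC1)C(C)C` stands at the high end of the two numbers measured in an assay on THP-1 cells for displacement of a labelled ligand from C-C chemokine receptor type 1 (Homo sapiens) (a higher number here means a weaker inhibitor, a lower number a stronger inhibitor), where compound 2 gives 388 nM. Among the compounds with values here, its only neighbour is compound 1 `CC(C)C(NC(=O)c1ccc2ccccc2c1)C(=O)N1CCC(c2ccc(Cl)cc2)CC1`, which in this assay gives 80 nM; the step of a 4.9-fold higher number from compound 1 to compound 2 (0.69 log units; beyond the scatter) came with isopropyl in place of naphthalen-2-yl on a carbonyl carbon. Compound 3 `CC(C)C(NC(=O)OCc1ccccc1)C(=O)N1CCC(c2ccc(Cl)cc2)CC1` has not been measured. It differs from compound 2 by benzyloxy in place of isopropyl on a carbonyl carbon; cut one bond further out, the change reads isopropylcarbonyl to benzyloxycarbonyl. Within the data shown here, the one step that bears on it is a 4.9-fold higher number from compound 1 to compound 2 (0.69 log units; beyond the scatter), in which an aromatic ring left that carbonyl carbon and the number rose. The change to compound 3 brings an aromatic ring back, though through an oxygen. Compound 3 is therefore expected to give in this assay an estimated 150 nM, within a range from 50 nM to 500 nM. The expected step of a 2.6-fold lower number from compound 2 to compound 3 (0.41 log units; beyond the scatter) is a modest lowering.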

Compound 3, half-maximal inhibitory concentration: 1080 nM
For compound 3 the middle estimate is 7.2-fold (0.86 log units) below the measured one; measured number above the stated range.
By their numbers in this assay, from the lowest: compound 1; then compound 2; then compound 3.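

In this assay, benzyloxy brings an aromatic ring back to this carbonyl carbon, yet the change gives a 2.8-fold higher number from compound 2 to compound 3 (0.44 log units; beyond the scatter), so an aromatic ring on this group does not by itself lower the number. Benzyloxy also has more heavy atoms than isopropyl, so a larger group here does not lower the number either, and the comparison with naphthalen-2-yl gives a 14-fold higher number from compound 1 to compound 3 (1.13 log units; beyond the scatter), the largest step among these three compounds. No evidence at hand accounts for this order.

As far as these compounds go, it remains open whether the oxygen or the ring goes with the rise, a question that a benzyl group on the same carbonyl carbon, keeping the ring without the oxygen, would address. Also open, from the compounds shown here alone, is whether a phenyl group set directly on that carbon would stand nearer to compound 1 or to compound 3.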